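This account rests on a few compounds, and the source may have more. Where it says the series, first, only, none or still open, it means among the compounds named here.

Measured in a functional assay on the whole organism with Mus musculus as the target; a lower number here means that less compound is needed, a higher number that more compound is needed for the effect:
- compound 1 `Cn1nc(-c2ccc(F)cc2F)n(C)c1=S` gives 2.37 mg/kg
- compound 2 `Cn1nc(-c2ccc(F)cc2)n(C)c1=S` gives 1 mg/kg
- compound 3 `Cn1nc(-c2c(Cl)cccc2Cl)n(C)c1=S` gives > 100 mg/kg, which is a limit and not a number

Of the two true numbers, compound 1 at 2.37 mg/kg holds the higher one. The value of compound 3 cannot be ranked beyond its limit.

Compound 4 `Cn1nc(-c2ccccc2F)n(C)c1=S` is related to compound 1 by hydrogen in place of fluoro on an aromatic carbon. This is hydrogen in place of fluoro on an aromatic carbon, meta to a fluoro group and para to a group of 8 heavy atoms, and that other fluoro stays.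

For the measured compounds named here, the one measured step of the same kind, made at the other fluoro, is a 2.4-fold lower number from compound 1 to compound 2 (0.37 log units; beyond the scatter). That single step guides size rather than direction, so a modest step is expected in this assay, in either direction and possibly none beyond the scatter.

The expected change is a 1.1-fold higher number from compound 1 to compound 4 (0.02 log units; within the scatter). For compound 4 the estimated value is 2.5 mg/kg, with an expected range from 0.8 mg/kg to 8 mg/kg.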

Compound 4, dose for half-maximal effect: 0.23 mg/kg
The estimate for compound 4 lay 11-fold (1.04 log units) above the measured number; measured number below the stated range.
By their numbers in this assay, from the lowest: compound 4; then compound 2; then compound 1. At a limit, above all of these: compound 3.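

In this assay, hydrogen in place of the fluoro that sits meta to a fluoro group and para to a group of 8 heavy atoms gives a 10-fold lower number from compound 1 to compound 4 (1.01 log units; beyond the scatter). The same change at the other fluoro gives a 2.4-fold lower number from compound 1 to compound 2 (0.37 log units; beyond the scatter), so in these two steps the change lowers the number at both places, with a large step at this position and a modest one at the other. No measurement shown bears on the cause of this step.

Still open, going by these compounds, is whether a methoxy group or an amine at this position would keep the number as low as in compound 4. Also open, on these data alone, is what the core of compound 1 gives with hydrogen in place of both fluoro groups.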